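The source may report more compounds than this note shows. Statements on the series, on what has been measured and on what is new or still open speak of the compounds shown alone.

Measured in an ADME assay on microsomes from liver (Rattus norvegicus) for metabolic stability, read by LC-MS, with a stated time of 45 min, tested at 2 uM; a higher number here means that more of the compound is left, a lower number that less of the compound is left:
- compound 1 `Cc1cc(OCc2ccc(F)cc2F)c(Br)c(=O)n1Cc1cccc(CN(C)C)c1`: 39%
- compound 2 `Cc1cc(OCc2ccc(F)cc2F)c(Br)c(=O)n1Cc1ccc(CN(C)C)cc1`: 53%
- compound 3 `Cc1cc(OCc2ccc(F)cc2F)c(Br)c(=O)n1Cc1ccc(C(=O)N(C)C)cc1`: 51%

Compound 2 stands at the upper end of these numbers, level within the scatter with compound 3 and clear of compound 1. Compound 4 `Cc1cc(OCc2ccc(F)cc2F)c(Br)c(=O)n1Cc1ccc(CNC(=O)CO)cc1` keeps the shared core but carries ((hydroxymethyl)carbonyl)amino in place of dimethylamino on a saturated chain carbon bound to an aromatic carbon. The closest guide also removes the (dimethylamino)methyl group, and it gave a number 2 percentage points lower from compound 2 to compound 3 (within the scatter). The larger step, a number 14 percentage points higher from compound 1 to compound 2 (beyond the scatter), only changes where that group sits, so it bears less on compound 4. For the measured compounds named here, no measured compound carries the new group, so the expectation is loose. No step beyond the scatter is expected in this assay, and the estimated change is a number 2 percentage points higher from compound 2 to compound 4 (within the scatter). The estimate for compound 4 is 55%, with an expected range from 40% to 72%.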

Compound 4, percent of the compound remaining: 82%
Compound 4: the middle estimate sits 27 percentage points below what was measured; measured number above the stated range.
By their numbers in this assay, from the lowest: compound 1; then compounds 3 and 2 (each within the scatter of the next); then compound 4.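

In this assay, the group on this saturated chain carbon clearly matters: ((hydroxymethyl)carbonyl)amino in place of dimethylamino gives a number 29 percentage points higher from compound 2 to compound 4 (beyond the scatter). Removing the amine alone does not account for this, since dimethylcarbamoyl in place of (dimethylamino)methyl left the number within the scatter, while (((hydroxymethyl)carbonyl)amino)methyl in place of dimethylcarbamoyl gives a number 31 percentage points higher from compound 3 to compound 4 (beyond the scatter). No measurement here explains the rise. The compounds shown leave open whether the hydroxyl or the amide carbonyl matters more. An acetyl amide, which lacks the hydroxyl, would help separate the two.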